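The compounds below may be only part of what the source reports. "The series", "measured", "known", "first", "only" and "open" are said of these compounds alone.

In an ADME assay on a cell-free system (plasma, Homo sapiens) for protein binding, compound 1 `COCc1nc2nc(C)cc(Nc3ccc(C(F)(F)F)cc3)n2n1` gives 75.6% and compound 2 `Cc1cc(Nc2ccc(C(F)(F)F)cc2)n2nc(CCO)nc2n1` gives 67%. Going by the values given here, these are the only two measurements so far, and the data show a 1.4-fold higher unbound fraction from compound 1 to compound 2 (0.13 log units; within the scatter), so compound 1 stands level with its one measured neighbour. Compound 3 `COCc1nc2nc(C)cc(Nc3ccc(S(F)(F)(F)(F)F)cc3)n2n1` keeps the core of compound 1 and alters a single group: a group of 6 heavy atoms (5 fluorine, 1 sulfur; no ring) in place of a group of 4 heavy atoms (1 carbon, 3 fluorine; no ring), on an aromatic carbon. The change sits on an aromatic carbon of a six-membered aromatic ring of carbon only, para to a large group. Among the compounds with values here, the one measured step swaps hydroxymethyl for methoxy at a different place, so it offers only a sense of scale and no direct evidence for this change. A small step in this assay towards less free compound is therefore expected, and it may stay within the scatter. The expected change is a 1.4-fold lower unbound fraction from compound 1 to compound 3 (0.13 log units; within the scatter). For compound 3 the estimated value is 82%, with an expected range from 68% to 92%.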

Compound 3, plasma protein binding: 91.7%
The estimate for compound 3 lay 2.2-fold (0.34 log units) (unbound fraction) above the measured number; the range from low to high includes it.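

In this assay the change on the aromatic carbon gives a 2.9-fold lower unbound fraction from compound 1 to compound 3 (0.47 log units; beyond the scatter) and so lies beyond the scatter, whereas the change elsewhere on the molecule gives a 1.4-fold higher unbound fraction from compound 1 to compound 2 (0.13 log units; within the scatter) and stays within it. This position, para to a large group, therefore responds measurably when trifluoromethyl gives way to the group of 6 heavy atoms (5 fluorine, 1 sulfur), even though both groups have 0 hydrogen-bond donors, 0 hydrogen-bond acceptors and no net charge. No available evidence accounts for the size of this shift.

The compounds shown leave open whether the same swap would have a similar effect with the side chain of compound 2 in place. They also leave open how an amine or a carboxylic acid on this aromatic carbon would compare.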